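The compounds below may be only part of what the source reports. "The series", "measured", "known", "first", "only" and "open" are said of these compounds alone.

In an assay on RBL-1 cells for inhibition of Polyunsaturated fatty acid 5-lipoxygenase (Rattus norvegicus) (on this read-out lower numbers stand for stronger inhibition and higher numbers for weaker inhibition), compound 2 `O=C(/C=C\N(O)c1ccccc1)c1ccc(F)cc1` gives 200 nM, the lowest of the two numbers in hand. Compound 1 `CN(O)/C=C\C(=O)c1ccc(Cl)cc1` gives 550 nM; compound 1 and compound 2 differ in two places, so that gap is not read as one step. Compound 3 `CN(O)/C=C\C(=O)c1ccc(F)cc1` has not yet been measured and differs from compound 2 in a single place: methyl in place of phenyl on an amine nitrogen. For compound 3 the expected step is a 2.3-fold higher number from compound 2 to compound 3 (0.35 log units; beyond the scatter), toward a weaker number, because compound 1 gives 550 nM while carrying the same methyl on that nitrogen. Compound 3 is estimated at 450 nM, within a range from 150 nM to 1400 nM.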

Compound 3, half-maximal inhibitory concentration: 5000 nM
Beside the measured number, compound 3's estimate is 11-fold (1.05 log units) below it; measured number outside the range, above it.
By their numbers in this assay, from the lowest: compound 2; then compound 1; then compound 3.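

The group on the amine nitrogen matters far more than compound 1 suggested: in this assay there is a 25-fold higher number from compound 2 to compound 3 (1.40 log units; beyond the scatter) with methyl in place of phenyl. The halogen on the aromatic carbon is no silent change either, with a 9.1-fold higher number from compound 1 to compound 3 (0.96 log units; beyond the scatter) when fluoro replaces chloro while methyl stays on that nitrogen. Nothing in hand explains either step.

On these data alone, whether chloro in place of fluoro would act the same way with phenyl on the nitrogen remains open. So does the number an ethyl or benzyl group on that nitrogen would give.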